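From Ethoxy to Propoxy, One Carbon Further

This account rests on a few compounds, and the source may have more. Where it says the series, first, only, none or still open, it means among the compounds named here.

Compound 3 `CCOC(=O)c1cnc(-c2cc(OC)ccc2OCC)[nH]c1=O` gives 0.3 mg/kg in a functional assay on the whole organism (strain Sprague-Dawley) for inhibition, with Rattus norvegicus as the target, with a stated time of 10 min (a higher number here means that more compound is needed for the effect, a lower number that less compound is needed), and so shares the lowest number among the three measured compounds. Compound 1 `CCCOc1ccc(OC)cc1-c1ncc(C(=O)O)c(=O)[nH]1` stands level with it at 0.3 mg/kg while compound 2 `CCOC(=O)c1cnc(-c2cc(OC)ccc2OC)[nH]c1=O` needs much more compound, at 5 mg/kg for the same effect.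

Compound 4 `CCCOc1ccc(OC)cc1-c1ncc(C(=O)OCC)c(=O)[nH]1` differs from compound 3 in one place, where ethoxy becomes propoxy (methyl in place of hydrogen on a saturated chain carbon, two bonds along the chain from an oxygen on an aromatic ring). In other words, a methyl takes the place of a hydrogen on a saturated chain carbon, two bonds along the chain from an oxygen on an aromatic ring.

Going by the values given here, the one measured step of this kind is the lengthening of methoxy to ethoxy (a 17-fold lower number from compound 2 to compound 3 (1.22 log units; beyond the scatter)), which was large. Compound 1 also carries propoxy, and its value of 0.3 mg/kg shows that this chain can go with a low number. A single step cannot show whether the trend continues, so a repeat of that large drop is not expected. The change expected in this assay is therefore no change at the digits printed from compound 3 to compound 4 (within the scatter) with no step beyond the scatter foreseen. Compound 4 is estimated at 0.3 mg/kg with an expected range from 0.1 mg/kg to 1 mg/kg in this measurement.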

Compound 4, dose for 50% inhibition: 0.7 mg/kg
Beside the measured number, compound 4's estimate is 2.3-fold (0.37 log units) below it; the range from low to high includes it.
By their numbers in this assay, from the lowest: compounds 1 and 3 (each within the scatter of the next); then compound 4; then compound 2.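

In this assay, the step from ethoxy to propoxy gives a 2.3-fold higher number from compound 3 to compound 4 (0.37 log units; beyond the scatter) and so goes the other way from the large drop on lengthening methoxy to ethoxy, which was a 17-fold lower number from compound 2 to compound 3 (1.22 log units; beyond the scatter) for the same kind of change one carbon earlier. The number therefore does not keep falling as this chain grows, although propoxy still stands well clear of methoxy, with a 7.1-fold lower number from compound 2 to compound 4 (0.85 log units; beyond the scatter) across the two-carbon extension. Going by these compounds alone, with propoxy held in place, the earlier compounds also gave no view of the acid against its ethyl ester, and that one-place comparison now reads a 2.3-fold higher number from compound 1 to compound 4 (0.37 log units; beyond the scatter) on going from the acid to the ester, a modest step that favours the acid.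

Whether a longer chain such as butoxy would raise the number further, or whether a branched chain such as isopropoxy would fit the same trend, stays open on these compounds alone. Nothing among the data shown accounts for why the number turns back upward at propoxy.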